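Swapping an Aryl Group on a Spiro-Lactone Core

The source may report more compounds than this note shows. Statements on the series, on what has been measured and on what is new or still open speak of the compounds shown alone.

Measured compounds:
- compound 1, `O=C1C=CC2(C=C1)OC(=O)C(I)=C2c1ccccc1`: 41500 nM
- compound 2, `O=C1C=CC2(C=C1)OC(=O)C(c1cc3ccccc3s1)=C2c1ccccc1`: 5900 nM
- compound 3, `COc1ccc(C2=C(c3ccccc3)C3(C=CC(=O)C=C3)OC2=O)cc1`: 5860 nM

These three share one core and differ only in the group on a double-bonded ring carbon. In a functional assay on MCF7 cells (Homo sapiens) for antiproliferative activity, read by MTT assay, with a stated time of 48 h (on this read-out lower numbers stand for stronger inhibition and higher numbers for weaker inhibition), compound 1 gives the highest number, and the two aryl-bearing compounds sit close together: the step of a 7.0-fold lower number from compound 1 to compound 2 (0.85 log units; beyond the scatter) and the step of a 7.1-fold lower number from compound 1 to compound 3 (0.85 log units; beyond the scatter) are both modest but beyond the scatter, while the step of a 1.0-fold lower number from compound 2 to compound 3 (0.00 log units; within the scatter) is within the scatter. Compound 2 therefore holds the second-highest of the three numbers, with compound 3 as its nearest neighbour and compound 1 as its furthest.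

The next compound, compound 4, `O=C1C=CC2(C=C1)OC(=O)C(c1ccc(CO)cc1)=C2c1ccccc1`, changes compound 2 in one place: 4-(hydroxymethyl)phenyl in place of 1-benzothiophen-2-yl on a double-bonded ring carbon. Going by the values given here, the step that bears most on it is the one from compound 2 to compound 3, since both replace one aryl group with a six-membered carbon ring carrying a single substituent, and that step was flat. A similar flat outcome is expected here, giving an estimated step of a 1.0-fold higher number from compound 2 to compound 4 (0.01 log units; within the scatter) and an estimate for compound 4 of 6000 nM, within a range from 2500 nM to 15000 nM.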

Compound 4, half-maximal inhibitory concentration: 5760 nM
Estimate against measurement, compound 4: 1.0-fold (0.02 log units) above; measured number inside the range.
By their numbers in this assay, from the lowest: compounds 4, 3 and 2 (each within the scatter of the next); then compound 1.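

In this assay, the step of a 1.0-fold lower number from compound 2 to compound 4 (0.01 log units; within the scatter) shows that this position accepts 4-(hydroxymethyl)phenyl, a single aromatic ring bearing a hydrogen-bond donor, without leaving the range of the fused 1-benzothiophen-2-yl. The step of a 1.0-fold lower number from compound 3 to compound 4 (0.01 log units; within the scatter) adds a change within the aryl group itself, as hydroxymethyl for methoxy on an aromatic carbon also stays within the scatter. The step of a 7.2-fold lower number from compound 1 to compound 4 (0.86 log units; beyond the scatter) is beyond the scatter, as are the steps from iodo to compound 2 and compound 3, so the three aryl groups stand apart from iodo but not from one another.

No measurement offered here explains why these aryl groups read alike. As far as these compounds go, whether an amine, a carboxylic acid or a longer chain in place of hydroxymethyl would move the number remains open.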